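A longer side chain on a shared core

The source may report more compounds than this note shows. Statements on the series, on what has been measured and on what is new or still open speak of the compounds shown alone.

Compound 1 `CCCOc1c(C(=O)N(C)Cc2cc(C(F)(F)F)cc(C(F)(F)F)c2)c(=O)n(C)c2ccccc12` carries a propyl chain on the oxygen of its aromatic ring. In an ADME assay for inhibition of phosphatidylcholine:ceramide cholinephosphotransferase 1 (Homo sapiens), read by mass spectrometry, with stated times of 60 min and 30 min (on this read-out lower numbers stand for stronger inhibition and higher numbers for weaker inhibition), compound 1 gives > 100000 nM, which is a limit of the assay and not a number. Compound 2 `COc1cc(CN(C)C(=O)c2c(OCCCC3CCN(C(=O)OC(C)(C)C)CC3)c3cnccc3n(C)c2=O)cc(OC)c1` shows the same limit in this assay, > 100000 nM. For the measured compounds named here, compound 3 `CN(Cc1cc(C(F)(F)F)cc(C(F)(F)F)c1)C(=O)c1c(OCCCC2CCN(C(=O)OC3(C)CC3)CC2)c2cccnc2n(C)c1=O` gives 850 nM in this assay, the only value among the three that is a number; the other two sit at the limit of > 100000 nM in this assay, at which 2 of the 3 values shown sit. Compound 4 `CN(Cc1cc(C(F)(F)F)cc(C(F)(F)F)c1)C(=O)c1c(OCCCC2CCCCC2)c2ccccc2n(C)c1=O` has not yet been measured. It differs from compound 1 by cyclohexyl in place of hydrogen on a saturated chain carbon, three bonds along the chain from an oxygen on an aromatic ring. Going by the values given here, no step between measured compounds is given, so the effect of this change rests on expectation alone. Among the compounds with values here, compound 3, the one compound with a number, also carries a ring at the end of a chain of this length, and on that basis compound 4 is expected to reach stronger inhibition than the limit of compound 1, with an at least 33-fold lower number from compound 1 to compound 4 (1.52 log units; beyond the scatter) as the expected step. The estimate for compound 4 in this assay is 3000 nM, with a range from 500 nM to 30000 nM.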

Compound 4, half-maximal inhibitory concentration: 14000 nM
Compound 4: middle estimate off by 4.7-fold (0.67 log units), on the low side, and the stated range covers the measured number.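

For the compounds shown here, replacing the propyl chain of compound 1 with the 3-cyclohexylpropyl chain of compound 4 gives an at least 7.1-fold lower number from compound 1 to compound 4 (0.85 log units; beyond the scatter) in this assay, the first step that can be read at this position. The entering cyclohexyl has 0 hydrogen-bond donors and 0 hydrogen-bond acceptors, so a ring of carbon only at this place is enough to give a measurable number. The step can be given only as a minimum because compound 1 stands at a limit of the assay, not at a number: the limit of > 100000 nM in this assay, at which 2 of the 4 values shown sit.

The compounds shown do not separate the effect of the ring from that of the added chain length, and a longer straight chain such as octyl would be needed to address this. As far as these compounds go, what an amine or a carboxylic acid on the cyclohexyl ring would do at this position also remains open.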